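This account rests on a few compounds, and the source may have more. Where it says the series, first, only, none or still open, it means among the compounds named here.

Measured so far:
compound 1, `Oc1nnc(Cc2cccc3ccccc23)c2ccccc12`: 4400 nM
compound 2, `C=CCn1nc(Cc2ccc(SC)cc2)c2ccccc2c1=O`: > 100000 nM

In a functional assay on aorta with Alpha-1D adrenergic receptor (Rattus norvegicus) as the target (a lower number here means that less compound is needed, a higher number that more compound is needed for the effect), compound 1 gives 4400 nM. In this assay compound 2 gives > 100000 nM, which is a limit of the assay and not a number. For the measured compounds named here, compound 2 thus sits at the limit of > 100000 nM in this assay, at which 1 of the 2 values shown sits, and no single-change step reaches it, since compound 1 differs from it in more than one place. Compound 3, `CSc1ccc(Cc2nn(C)c(=O)c3ccccc23)cc1`, has yet to be measured in this assay. It differs from compound 2 by hydrogen in place of vinyl on a saturated chain carbon bound to an aromatic nitrogen; the same difference, cut one bond further out, reads allyl to methyl. Going by the values given here, no measured step covers a change of this kind here. Compound 2 gives only a limit. The change in compound 3 is small, and it is expected to make no step beyond the scatter, in no definite direction, a number no higher from compound 2 to compound 3 (the limit leaves the size open). Compound 3 is therefore estimated at 100000 nM, expected between 20000 nM and 300000 nM, and most likely reported again as a limit.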

Compound 3, half-maximal effective concentration: 930 nM
Beside the measured number, compound 3's estimate is 110-fold (2.03 log units) above it; measured number below the stated range.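

For the compounds shown here, this is the first single-change step, and it shows that this assay is highly sensitive to the group at this position: hydrogen in place of vinyl on a saturated chain carbon bound to an aromatic nitrogen, which reads as allyl to methyl, gives an at least 100-fold lower number from compound 2 to compound 3 (2.03 log units; beyond the scatter). A change of only 2 heavy atoms is therefore enough to bring the series from the edge of the measurable range to a measured number. Compound 2 gives > 100000 nM, a limit of the assay and not a number, so the step has no upper bound: the limit of > 100000 nM in this assay, at which 1 of the 3 values shown sits.

One step cannot show whether the difference follows from the chain length or from the double bond. On these data alone, an ethyl or propyl group at this position would separate the two, and an amine at the chain end remains open as well.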